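The compounds below may be only part of what the source reports. "The series", "measured", "known", "first", "only" and "open" are said of these compounds alone.

Of the compounds shown here, three built on one shared core have been tested in a functional assay on SMMC-7721 cells (Homo sapiens) for cytotoxicity, read by MTT assay, with a stated time of 4 days; a higher number here means a weaker inhibitor, a lower number a stronger inhibitor. Compound 1 `C=C1C(=O)[C@]23C[C@@]1(O)CC[C@H]2c1ccc(O)c(C)c1[C@@H]3Cn1cc(-c2ccc(C)cc2)nn1` gives 920 nM. Compound 2 `C=C1C(=O)[C@]23C[C@@]1(O)CC[C@H]2c1ccc(O)c(C)c1[C@@H]3Cn1cc(-c2ccc(Br)cc2)nn1` gives 1300 nM, and compound 3 `C=C1C(=O)[C@]23C[C@@]1(O)CC[C@H]2c1ccc(O)c(C)c1[C@@H]3Cn1cc(-c2ccc(Cl)cc2)nn1` gives 670 nM. Compound 2 carries the highest of the three numbers, yet every gap between them is small: a 1.4-fold higher number from compound 1 to compound 2 (0.15 log units; within the scatter), a 1.4-fold lower number from compound 1 to compound 3 (0.14 log units; within the scatter) and a 1.9-fold lower number from compound 2 to compound 3 (0.29 log units; within the scatter), so none of the three can be set apart from the others on these figures.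

Compound 4 `C=C1C(=O)[C@]23C[C@@]1(O)CC[C@H]2c1ccc(OS(=O)(=O)c2ccc(C)cc2)c(C)c1[C@@H]3Cn1cc(-c2ccc(Br)cc2)nn1` arises from compound 2 by a single change, ((4-methylphenyl)sulfonyl in place of hydrogen on an oxygen on an aromatic ring). For the measured compounds named here, none of the measured steps touches that oxygen; all three exchange one group for another on an aromatic carbon, and all three stay within the scatter. Going by the values given here, there is thus no measured step that speaks directly to the change from compound 2 to compound 4, and the group that enters is larger than anything varied among the three measured compounds. Compound 4 is expected to give roughly 2000 nM in this assay, within a wide range from 600 nM to 7000 nM. The estimated step from compound 2 is a 1.5-fold higher number from compound 2 to compound 4 (0.19 log units; within the scatter), a cautious guess at a modest weakening rather than a reading of the measured steps.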

Compound 4, half-maximal inhibitory concentration: 4320 nM
Compound 4: middle estimate off by 2.2-fold (0.33 log units), on the low side, and the stated range covers the measured number.
By their numbers in this assay, from the lowest: compounds 3, 1 and 2 (each within the scatter of the next); then compound 4.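

Placing (4-methylphenyl)sulfonyl on the oxygen on the aromatic ring produces the only step shown that lies beyond the scatter: in this assay, there is a 3.3-fold higher number from compound 2 to compound 4 (0.52 log units; beyond the scatter). This marks the oxygen as a place where a change registers in this assay, which the exchanges on an aromatic carbon among compounds 1, 2 and 3 could not show, and it also shows that the free hydroxy is not needed for a measurable number, since compound 4 still gives 4320 nM. No measurement at hand accounts for the step.

The single change replaces the hydrogen with a large group, so the compounds shown cannot separate the loss of the hydroxy from the entry of the sulfonyl group with its aromatic ring; a methyl ether, an acetyl ester or a methanesulfonyl group on the same oxygen, or an amine in place of the hydroxy, would bear on that. Going by these compounds, whether the same change has a similar effect with the methyl or chloro group of compound 1 and compound 3 also remains open.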